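This account rests on a few compounds, and the source may have more. Where it says the series, first, only, none or still open, it means among the compounds named here.

Compound 1, `C[C@H](c1ccc(F)cc1)N(Cc1cc(C(=O)O)ccc1F)C(=O)c1cnc2ccccc2c1`, is measured in an assay on CHO T-rex cells for antagonist activity at transient receptor potential cation channel subfamily M member 8 (Homo sapiens), read by calcium flux, with a stated time of 20 min (a lower number here means a stronger inhibitor, a higher number a weaker inhibitor), at 446 nM. Compound 2, `O=C(O)c1cccc(CN(Cc2ccc(F)cc2)C(=O)c2cnc3ccccc3c2)c1`, gives in this assay only > 9350 nM, a limit of the measurement rather than a number. Compound 2 thus stands at the top of the two values shown, on the line of the limit of > 9350 nM in this assay, at which 1 of the 2 values shown sits, while compound 1 sits well inside the measured range; the two structures differ in more than one place, so the pair shows only its two values. Compound 3, `C[C@H](c1cccc(Cl)c1)N(Cc1cccc(C(=O)O)c1)C(=O)c1cnc2ccccc2c1`, is not yet measured. It differs from compound 2 by 1-(3-chlorophenyl)ethyl in place of 4-fluorobenzyl on an amide-type nitrogen. Among the measured compounds shown here, no step between measured compounds matches this change. Compound 3 shares with compound 1 a branched ethyl linker of this kind, and compound 1 gave 446 nM, so compound 3 is expected to come out at a measurable number, by the step of an at least 6.2-fold lower number from compound 2 to compound 3 (0.79 log units; beyond the scatter). Compound 3 is therefore estimated at 1500 nM, in the range 400 nM to 6000 nM.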

Compound 3, half-maximal inhibitory concentration: 62 nM
For compound 3 the middle estimate is 24-fold (1.38 log units) above the measured one; the measured number lies below the stated range.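

At the amide-type nitrogen, 1-(3-chlorophenyl)ethyl in place of 4-fluorobenzyl gives an at least 150-fold lower number from compound 2 to compound 3 (2.17 log units; beyond the scatter) in this assay, so a change at this one position, with the rest of the structure the same, can move the value very far, which the earlier pair, differing in more than one place, could not show. The change brings several things at once: chlorine instead of fluorine, a different ring position for the halogen, and a defined stereocentre on a branched linker. Compound 2 gives only a limit, so the step is a bound rather than an exact size, because that compound's reading is: the limit of > 9350 nM in this assay, at which 1 of the 3 values shown sits.

Which of these features carries the step stays open. So does how 3-chlorobenzyl, the opposite stereocentre or a longer chain would read at this nitrogen.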